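The source may hold more compounds than are shown below. What is called first, only, known or untested is meant among the compounds shown, and "the series" means these compounds.

Compound 1 `COc1ccc(/C=C2\SC(=O)N(CCNC(=O)Nc3c(C)n(C)n(-c4ccccc4)c3=O)C2=O)cc1` and compound 3 `COc1ccc(/C=C2\SC(=O)N(CC(=O)Nc3c(C)n(C)n(-c4ccccc4)c3=O)C2=O)cc1` share a methoxyphenyl end but differ in their cores; the difference between the two cores is not broken down here. In a functional assay on MCF7 cells (Homo sapiens) for inhibition, read by MTT assay, with a stated time of 48 h (on this read-out higher numbers stand for weaker inhibition and lower numbers for stronger inhibition), compound 1 gives 5140 nM, while compound 3 gives 75600 nM, the highest number of the three. Compound 2 `Cc1c(NC(=O)NCCN2C(=O)S/C(=C\c3ccc([N+](=O)[O-])cc3)C2=O)c(=O)n(-c2ccccc2)n1C` arises from compound 1 by nitro in place of methoxy on an aromatic carbon, and the step is a 3.6-fold higher number from compound 1 to compound 2 (0.56 log units; beyond the scatter); in this assay compound 2 gives 18600 nM. Compound 4 `Cc1c(NC(=O)CN2C(=O)S/C(=C\c3ccc([N+](=O)[O-])cc3)C2=O)c(=O)n(-c2ccccc2)n1C`, not yet measured, arises from compound 3 by the same change, (nitro in place of methoxy on an aromatic carbon). Since the change occurs only twice among these compounds, the expectation rests on a single measured step. Compound 4 is expected to give a step of a 2.9-fold higher number from compound 3 to compound 4 (0.46 log units; beyond the scatter), because the corresponding step was a 3.6-fold higher number from compound 1 to compound 2 (0.56 log units; beyond the scatter). For compound 4 the estimate in this assay is 220000 nM, within 60000 nM to 700000 nM.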

Compound 4, half-maximal inhibitory concentration: 82400 nM
For compound 4 the middle estimate is 2.7-fold (0.43 log units) above the measured one; low and high end bracket the measured number.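

In this assay the change from 4-methoxyphenyl to 4-nitrophenyl gives a 1.1-fold higher number from compound 3 to compound 4 (0.04 log units; within the scatter), so the size of this step does not carry over from one core to the other: the same change on two cores in this assay, a 3.6-fold higher number (0.56 log units; beyond the scatter) from compound 1 to compound 2 and a 1.1-fold higher number (0.04 log units; within the scatter) from compound 3 to compound 4, 3.3-fold (0.52 log units) apart, beyond the scatter of two such steps

The step therefore has to be read separately on each core in this series. Going by these compounds alone, two pairs show only that the step can differ between these cores; they give no rule for other cores and do not show which part of the core difference goes with the gap.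

The compounds shown leave open how an amine or a carboxylic acid in the same place would behave on either core. They also leave open whether a longer chain on the core of compound 3 would change the step.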